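From 2,4-dichlorophenyl to 3,4-dichlorophenyl

A few compounds are considered here, and "the series" means these few. Any claim that something is new, unique, unknown or untested is made for them only; others in the source may bear on it.

In a functional assay on HeLa cells (Homo sapiens) for cytotoxicity, read by MTT assay, with a stated time of 24 h (a lower number here means a stronger inhibitor, a higher number a weaker inhibitor), compound 1 (`COc1cc(/C=C2\CN(C)C/C(=C\c3ccccc3F)C2=O)cc(OC)c1OC`) gives 3220 nM. Compound 2 (`COc1cc(/C=C2\CN(C)C/C(=C\c3ccc(Cl)c(Cl)c3)C2=O)cc(OC)c1`) gives 6900 nM in this assay. Compound 3 (`COc1cc(/C=C2\CN(C)C/C(=C\c3ccc(Cl)cc3Cl)C2=O)cc(OC)c1OC`) gives > 20000 nM, which is a limit of the assay and not a number. Its standing on the numbers is thus (the limit of > 20000 nM in this assay, at which 1 of the 3 values shown sits).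

Compound 4 (`COc1cc(/C=C2\CN(C)C/C(=C\c3ccc(Cl)c(Cl)c3)C2=O)cc(OC)c1OC`) has the same atoms as compound 3, joined differently: 3,4-dichlorophenyl in place of 2,4-dichlorophenyl on a double-bonded chain carbon bound to a double-bonded ring carbon.

Among the measured compounds shown here, one measured step bears directly on this change: an at least 6.2-fold higher number from compound 1 to compound 3 (0.79 log units; beyond the scatter), with 2,4-dichlorophenyl in place of 2-fluorophenyl. Compound 2 also bears on it, as it carries the 3,4-dichlorophenyl group and gives 6900 nM, although its other aryl group differs. On these grounds, a step toward a lower number in this assay, beyond the scatter, is expected, estimated at an at least 3.3-fold lower number from compound 3 to compound 4 (0.52 log units; beyond the scatter). Its size remains loose, as compound 3 has only a limit. For compound 4 the estimated value is 6000 nM, with an expected range of 2500 nM to 15000 nM.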

Compound 4, half-maximal inhibitory concentration: 13500 nM
For compound 4 the middle estimate is 2.3-fold (0.35 log units) below the measured one; the measured number falls inside the stated range.
By their numbers in this assay, from the lowest: compound 1; then compounds 2 and 4 (each within the scatter of the next). At a limit, above all of these: compound 3.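

In this assay, 3,4-dichlorophenyl in place of 2,4-dichlorophenyl on a double-bonded chain carbon bound to a double-bonded ring carbon gives a measured number where there was only a limit, but the step, an at least 1.4-fold lower number from compound 3 to compound 4 (0.17 log units; that floor lies within the scatter), does not establish a change beyond the scatter. Methoxy in place of hydrogen on an aromatic carbon gives a 2.0-fold higher number from compound 2 to compound 4 (0.29 log units; within the scatter), so no effect of this change can be told from the scatter. Against 2-fluorophenyl at the same place, 3,4-dichlorophenyl gives a 4.2-fold higher number from compound 1 to compound 4 (0.62 log units; beyond the scatter), so 2-fluorophenyl keeps the lower number of this one pair.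

From the compounds shown here alone, compound 3 stands at a limit of the assay, so the true size of its step to compound 4 stays open: the limit of > 20000 nM in this assay, at which 1 of the 4 values shown sits. Also open, going by these compounds, is how an aryl group carrying a dimethylamino group or a carboxylic acid at this place would read in this assay.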